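A few compounds are considered here, and "the series" means these few. Any claim that something is new, unique, unknown or untested is made for them only; others in the source may bear on it.

Series so far, in a functional assay on A549 cells (Homo sapiens) for antiproliferative activity, read by MTT assay, with a stated time of 72 h; on this read-out higher numbers stand for weaker inhibition and lower numbers for stronger inhibition:
compound 1 `COc1cc2c(Oc3c(F)cc(NC(=O)NN4C(=O)CSC4c4c(F)cccc4F)cc3F)ccnc2cc1OCCCN1CCCC1`: 560 nM
compound 2 `CCN1CCN(CCCOc2cc3nccc(Oc4c(F)cc(NC(=O)NN5C(=O)CSC5c5c(F)cccc5F)cc4F)c3cc2OC)CC1`: 350 nM
compound 3 `COc1cc2c(Oc3c(F)cc(NC(=O)NN4C(=O)CSC4c4c(F)cccc4F)cc3F)ccnc2cc1OCCCN1CCC(C)CC1`: 970 nM

Compound 3, at 970 nM, cannot be separated from compound 1 within the scatter. Within the data shown here, the only step reaching it that goes beyond the scatter is a 2.8-fold higher number from compound 2 to compound 3 (0.44 log units; beyond the scatter).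

Compound 4 `COc1cc2c(Oc3c(F)cc(NC(=O)NN4C(=O)CSC4c4c(F)cccc4F)cc3F)ccnc2cc1OCCCN1C[C@H]2CCCC[C@H]2C1` changes one group of compound 3: a group of 9 heavy atoms (8 carbon, 1 nitrogen; one five-membered non-aromatic ring with 1 hetero atom, one six-membered non-aromatic ring of carbon only) in place of a group of 7 heavy atoms (6 carbon, 1 nitrogen; one six-membered non-aromatic ring with 1 hetero atom), on a saturated chain carbon, three bonds along the chain from an oxygen on an aromatic ring.

All three measured steps were made at this same place on the chain, and they are small. a 1.6-fold lower number from compound 1 to compound 2 (0.20 log units; within the scatter) and a 1.7-fold higher number from compound 1 to compound 3 (0.24 log units; within the scatter) are both within the scatter, and even the largest, a 2.8-fold higher number from compound 2 to compound 3 (0.44 log units; beyond the scatter), is modest. Among the measured compounds shown here, no measured compound carries the entering group, so the expectation rests only on the size of these steps. The step expected in this assay is a 1.2-fold lower number from compound 3 to compound 4 (0.08 log units; within the scatter), which means no clear change beyond the scatter.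

The estimated value for compound 4 is 800 nM, with an expected range of 350 nM to 1800 nM.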

Compound 4, half-maximal inhibitory concentration: 1930 nM
The estimate for compound 4 lay 2.4-fold (0.38 log units) below the measured number; the whole stated range lies below it.
By their numbers in this assay, from the lowest: compounds 2, 1, 3 and 4 (each within the scatter of the next, the first and the last beyond it).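

In this assay, the group with a five-membered non-aromatic ring and a six-membered carbon ring cannot be separated from 4-methylpiperidin-1-yl at this place on the chain, at a 2.0-fold higher number from compound 3 to compound 4 (0.30 log units; within the scatter). It does separate from the other two amines, with a 3.4-fold higher number from compound 1 to compound 4 (0.54 log units; beyond the scatter) and a 5.5-fold higher number from compound 2 to compound 4 (0.74 log units; beyond the scatter), the latter now the largest step at this position, though still modest. Nothing on hand accounts for these steps.

Open is whether the 2 defined stereocentres of the entering group matter, since compound 4 is the only stereoisomer shown. Also open, from the compounds shown here alone, is how morpholin-4-yl, a dimethylamino group or a longer chain carrying 4-ethylpiperazin-1-yl would stand in this assay.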